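The compounds below may be only part of what the source reports. "The series", "measured", "known", "first", "only" and "open" are said of these compounds alone.

Measured so far:
compound 1, `COc1cccc(OCCC(C)(C)C)c1C(=O)/C=C/c1ccc(O)cc1`: > 30000 nM
compound 2, `CC(C)(C)CCOc1cccc(O)c1C(=O)/C=C/c1ccc(C(=O)O)cc1`: 2800 nM

In an assay on THP-1 cells for inhibition of nuclear factor NF-kappa-B complex (Homo sapiens), with stated times of 2 h and 16 h (on this read-out lower numbers stand for stronger inhibition and higher numbers for weaker inhibition), compound 2 gives 2800 nM, which is the only numerical result so far. For compound 1 the result in this assay is a limit, > 30000 nM, and not a number; this is recorded as the limit of > 30000 nM in this assay, at which 1 of the 2 values shown sits. Going by the values given here, compound 1 and compound 2 differ in more than one place, so their two values show only that compound 2 is within the measured range while compound 1 is not.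

Compound 3, `CC(C)(C)CCOc1cccc(O)c1C(=O)/C=C/c1ccc(O)cc1`, is not yet measured in this assay. It differs from compound 2 by hydroxy in place of carboxy on an aromatic carbon. The replacement is a hydroxy in place of carboxy on an aromatic carbon, para to a large group. Among the compounds with values here, no measured pair isolates this change, so the size of the step is open. Compound 3 is expected to be weaker than compound 2, a step of a 3.2-fold higher number from compound 2 to compound 3 (0.51 log units; beyond the scatter), since compound 1, which also carries the hydroxy at this position, gives > 30000 nM. The estimate for compound 3 in this assay is 9000 nM, within 1500 nM to 30000 nM.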

Compound 3, half-maximal inhibitory concentration: 3000 nM
The estimate for compound 3 lay 3.0-fold (0.48 log units) above the measured number; the measured number falls inside the stated range.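

In this assay, exchanging carboxy for hydroxy on an aromatic carbon, para to a large group, makes no difference beyond the scatter: a 1.1-fold higher number from compound 2 to compound 3 (0.03 log units; within the scatter), so the 4-carboxyphenyl and 4-hydroxyphenyl groups cannot be told apart on this read-out. The 4-hydroxyphenyl group therefore cannot by itself explain the result for compound 1, and the change that separates the two hydroxyphenyl compounds, hydrogen in place of methyl on an oxygen on an aromatic ring, gives a step beyond the scatter: an at least 10-fold lower number from compound 1 to compound 3 (1.00 log units; beyond the scatter). That step starts from a limit and not a number, so only its minimum size is known: the limit of > 30000 nM in this assay, at which 1 of the 3 values shown sits.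

It remains open whether hydrogen in place of methyl on that oxygen would give a similar step in a compound carrying the 4-carboxyphenyl group, since only one such pair is shown. Also open, going by these compounds, is how an amine or an amide would read at the place held by carboxy and hydroxy, and whether a longer chain on the other oxygen of the shared core would change the values.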